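The compounds below may be only part of what the source reports. "The series", "measured", "known", "first", "only" and "open" are said of these compounds alone.

Measured compounds:
- compound 1, `CCOC(=O)c1cnc(-c2ccc(F)cc2)nc1NN1C(=O)C=C(C)C1=O`, a functional assay on Jurkat cells for inhibition of nuclear factor NF-kappa-B complex (Homo sapiens); on this read-out lower numbers stand for stronger inhibition and higher numbers for weaker inhibition: 700 nM
- compound 2, `CCOC(=O)c1cnc(C2CC2)nc1NN1C(=O)C=C(C)C1=O`, this assay: 1000 nM
- compound 3, `CCOC(=O)c1cnc(Cc2ccccc2)nc1NN1C(=O)C=C(C)C1=O`, this assay: 7000 nM

Compound 3 gives the highest number of the three. Its nearest neighbour is compound 2 (a 7.0-fold higher number from compound 2 to compound 3 (0.85 log units; beyond the scatter)) and the furthest is compound 1 (a 10-fold higher number from compound 1 to compound 3 (1.00 log units; beyond the scatter)); both gaps lie beyond the scatter, so compound 3 is the weakest inhibitor of the measured set. Compound 1 and compound 2 sit within the scatter of each other (a 1.4-fold higher number from compound 1 to compound 2 (0.15 log units; within the scatter)).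

Compound 4, `CCOC(=O)c1cnc(Sc2ccccc2)nc1NN1C(=O)C=C(C)C1=O`, is not yet measured. Relative to compound 3 the change is phenylsulfanyl in place of benzyl on an aromatic carbon. Within the data shown here, no measured step involves phenylsulfanyl; the steps that bear on the position are those that replace benzyl, and both moved the number by a modest amount. An aromatic ring linked through one atom is kept, so the starting point of compound 3 remains the closest guide, and a step of about a 2.0-fold lower number from compound 3 to compound 4 (0.30 log units; within the scatter) is expected, with the direction uncertain and possibly within the scatter. Compound 4 is therefore estimated at 3500 nM in this assay. The range for compound 4 is expected to run from 1000 nM to 12000 nM.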

Compound 4, half-maximal inhibitory concentration: 1000 nM
Compound 4: middle estimate off by 3.5-fold (0.54 log units), on the high side; the measured number falls inside the stated range.
By their numbers in this assay, from the lowest: compounds 1, 2 and 4 (each within the scatter of the next); then compound 3.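

On the aromatic carbon between two ring nitrogen atoms, phenylsulfanyl in place of benzyl in this assay gives a clear separation (a 7.0-fold lower number from compound 3 to compound 4 (0.85 log units; beyond the scatter)), so two groups that each carry 7 heavy atoms and one six-membered aromatic ring of carbon only are not interchangeable here, although they differ in the linking atom alone. Compound 4 cannot be told apart from the other two compounds (no change at the digits printed from compound 2 to compound 4 (within the scatter) and a 1.4-fold higher number from compound 1 to compound 4 (0.15 log units; within the scatter), both within the scatter), which leaves compound 3 as the only weak member and the weakest inhibitor of the four; an aromatic ring linked through one atom therefore does not by itself go with the weaker number, and benzyl is the exception among the groups shown. No data are at hand that explain the gap between the sulfur link and the carbon link.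

Still open, from the compounds shown here alone, is how an oxygen link as in phenoxy, or a nitrogen link as in anilino, would compare at this position. Also open, going by these compounds, is whether a longer chain such as phenethyl, or a small amine such as dimethylamino, would stay with compounds 1, 2 and 4 or fall with compound 3.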